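Amide aryl exchange and human microsomal clearance

This account rests on a few compounds, and the source may have more. Where it says the series, first, only, none or still open, it means among the compounds named here.

Measured so far:
compound 1 `COc1ccc(NC(=O)[C@H]2CN(C)C[C@@H]2c2ccc(/C=C/C(=O)Nc3ccccc3N)cc2)cc1` — 14 mL/min/kg
compound 2 `CC(C)c1ccc(NC(=O)[C@H]2CN(C)C[C@@H]2c2ccc(/C=C/C(=O)Nc3ccccc3N)cc2)cc1` — 10 mL/min/kg
compound 3 `Cc1cccc(NC(=O)[C@H]2CN(C)C[C@@H]2c2ccc(/C=C/C(=O)Nc3ccccc3N)cc2)c1` — 14 mL/min/kg
compound 4 `Cc1ccc(NC(=O)[C@H]2CN(C)C[C@@H]2c2ccc(/C=C/C(=O)Nc3ccccc3N)cc2)cn1` — not yet measured

In an in vitro ADME assay on microsomes from liver (Homo sapiens) for pharmacokinetics, read by LC-MS, with a stated time of 10 min, tested at 1 uM (on this read-out lower numbers stand for slow clearance and higher numbers for fast clearance), the three measured compounds sit close together. Compound 2 gives 10 mL/min/kg and its numbers to the other two lie within the scatter: a 1.4-fold lower number from compound 1 to compound 2 (0.15 log units; within the scatter) and a 1.4-fold higher number from compound 2 to compound 3 (0.15 log units; within the scatter) are both within the scatter, as is no change at the digits printed from compound 1 to compound 3 (within the scatter). Going by the values given here, no compound of the three can be set apart from the others on these numbers.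

Compound 4 arises from compound 2 by 6-methylpyridin-3-yl in place of 4-isopropylphenyl on an amide-type nitrogen. Among the compounds with values here, the steps that bear on this are those that exchange the whole aryl group on the amide-type nitrogen, no change at the digits printed from compound 1 to compound 3 (within the scatter) and a 1.4-fold higher number from compound 2 to compound 3 (0.15 log units; within the scatter), and both were within the scatter. Within the data shown here, none of the measured steps, however, replaces a ring of carbon only with a ring carrying a hetero atom, so the data do not cover that part of the change.

On the steps seen, no step beyond the scatter is expected in this assay. Compound 4 is estimated at 10 mL/min/kg, with a range from 5 mL/min/kg to 20 mL/min/kg. That estimate corresponds to an expected step of no change at the digits printed from compound 2 to compound 4 (within the scatter).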

Compound 4, clearance: 8 mL/min/kg
Compound 4: the middle estimate sits 1.3-fold (0.10 log units) above what was measured, and the stated range covers the measured number.
By their numbers in this assay, from the lowest: compounds 4, 2, 1 and 3 (each within the scatter of the next).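

Compound 4 brings the first ring with a hetero atom onto the amide-type nitrogen, a change the earlier exchanges of one ring of carbon only for another did not cover. In this assay the three new steps, a 1.3-fold lower number from compound 2 to compound 4 (0.10 log units; within the scatter) and a 1.8-fold lower number from compound 3 to compound 4 (0.24 log units; within the scatter) and a 1.8-fold lower number from compound 1 to compound 4 (0.24 log units; within the scatter), all stay within the scatter, so 6-methylpyridin-3-yl, with its ring nitrogen and its hydrogen-bond acceptor, does not set compound 4 apart from the compounds carrying 4-isopropylphenyl, 3-methylphenyl or 4-methoxyphenyl. Nothing among the available data explains these numbers or shows what the microsomes act on in any of the four compounds.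

From the compounds shown here alone, it remains open whether an aryl group on the amide-type nitrogen bearing a basic amine or a carboxylic acid, or a saturated piperidine ring in place of the aryl group, would give a step beyond the scatter in this assay. All four compounds also share the same core, so these numbers say nothing about changes made anywhere other than on the amide-type nitrogen.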